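This account rests on a few compounds, and the source may have more. Where it says the series, first, only, none or still open, it means among the compounds named here.

For the measured compounds named here, in a functional assay on HL-60 cells (Homo sapiens) for antiproliferative activity, read by MTT assay (a lower number here means a stronger inhibitor, a higher number a weaker inhibitor), compound 1 `O[C@@H]1[C@@H](OCc2ccccc2)[C@H](OCc2ccccc2)[C@@H](COCc2ccccc2)O[C@@H]1CC1CCCCC1` gives 17200 nM, the higher of the two numbers measured so far, which makes it the weaker of the pair. Compound 2 `O[C@@H]1[C@@H](OCc2ccccc2)[C@H](OCc2ccccc2)[C@@H](COCc2ccccc2)O[C@H]1CC1CCCCC1` gives 4100 nM. Compound 3 `O[C@@H]1[C@@H](O)[C@H](Cc2ccccc2)O[C@H](COCc2ccccc2)[C@H]1O` has no number and is reported as "not active" (no number reported).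

Compound 4 `O[C@@H]1[C@@H](OCc2ccccc2)[C@H](OCc2ccccc2)[C@@H](COCc2ccccc2)O[C@@H]1c1ccccc1` keeps the core of compound 1 but carries phenyl in place of cyclohexylmethyl on a saturated ring carbon. The new group sits next to the ring oxygen and next to the ring atom that bears a hydroxy group.

Going by the values given here, only one measured step is available, and it does not involve this swap. It shows a 4.2-fold lower number from compound 1 to compound 2 (0.62 log units; beyond the scatter), and the evidence for it is the fact that compounds 1 and 2 differ only in the configuration as drawn. That step shows that the number can move with a change at this ring carbon, but it does not show which way a new group would push it. Among the compounds with values here, with that step from compound 2 as the only guide to size, a shift of similar magnitude in either direction is possible, and no clear move beyond the scatter is expected. The estimated change is a 1.1-fold lower number from compound 1 to compound 4 (0.06 log units; within the scatter). Compound 4 could also return no number, as compound 3 did. If a number is reported, compound 4 is expected at 15000 nM, within a range of 5000 nM to 45000 nM.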

Compound 4, half-maximal inhibitory concentration: "not active" (no number reported)
The entry for compound 4 holds no number; no gap can be computed for the estimate.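

Compound 4 is reported as "not active" in this assay, without a number, so no new step can be read from compound 1 to compound 4. Nothing shown here accounts for this result. The compounds shown leave open how phenyl would read out with the other configuration at that ring carbon, as drawn in compound 2.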